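Triazole substituent removal on the lactone series

This account rests on a few compounds, and the source may have more. Where it says the series, first, only, none or still open, it means among the compounds named here.

Compound 1 `O=C1O/C(=C\Cn2cc(-c3cc(C(F)(F)F)cc(C(F)(F)F)c3)nn2)C(OCc2ccccc2)=C1OCc1ccccc1` reaches only the limit of the assay: in a functional assay on HepG2 cells (Homo sapiens) for antiproliferative activity, read by MTT assay, with a stated time of 72 h (on this read-out lower numbers stand for stronger inhibition and higher numbers for weaker inhibition), compound 1 gives > 100000 nM, a limit and not a number. For the measured compounds named here, compound 2 `CC(C)(C)c1cn(C[C@H](O)[C@H]2OC(=O)C(OCc3ccccc3)=C2OCc2ccccc2)nn1` is the only member of the series with a measured number; in this assay compound 2 gives 29200 nM. Going by the values given here, the one further value shown, that of compound 1, is a limit (the limit of > 100000 nM in this assay, at which 1 of the 2 values shown sits). Among the compounds with values here, no step between two measured compounds differing in a single place is available, so no measured step can be used as a guide.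

Compound 3 `O=C1O[C@H]([C@@H](O)Cn2ccnn2)C(OCc2ccccc2)=C1OCc1ccccc1` remains to be measured. It differs from compound 2 by hydrogen in place of tert-butyl on an aromatic carbon, the change reading 4-(tert-butyl)-1H-1,2,3-triazol-1-yl to 1H-1,2,3-triazol-1-yl.

With no measured step of this kind in the series, the expectation rests on the single number for compound 2 alone. The step from compound 2 to compound 3 is expected to be a modest loss, about a 1.9-fold higher number from compound 2 to compound 3 (0.27 log units; within the scatter), not much beyond the usual scatter. Compound 3 is therefore estimated at 55000 nM in this assay, within the range 15000 nM to 150000 nM, with a real chance that only a limit is reported.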

Compound 3, half-maximal inhibitory concentration: > 100000 nM
Compound 3 gave a limit, no number (the forecaster's own chance of this, stated with the estimate: 35%); middle value at least 1.8-fold (0.25 log units) away from the limit.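

Hydrogen in place of tert-butyl on an aromatic carbon of the five-membered aromatic ring gives an at least 3.4-fold higher number from compound 2 to compound 3 (0.53 log units; beyond the scatter), the first single-place change that can be read in this series, and it lies beyond the scatter. In this assay, going by these compounds, compound 3 gives > 100000 nM, a limit and not a number, so the printed step sets only a minimum size for this change and its full size stays unknown. The measured number of compound 2 therefore goes with the tert-butyl in this pair, and the unsubstituted 1H-1,2,3-triazol-1-yl side chain adds to the compounds at the edge of the assay: the limit of > 100000 nM in this assay, at which 2 of the 3 values shown sit.

On these data alone, whether the read-out at this carbon tracks the group placed there stays open, as methyl, isopropyl, a plain phenyl, an amine or a carboxylic acid would each be needed to place the tert-butyl within a wider set. Compound 1 carries an aryl group with two trifluoromethyl groups on the same ring but also differs from compound 2 elsewhere, so it gives no separate reading of this position.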